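A Thioether and Two Selenoethers in One Cell Assay

A few compounds are considered here, and "the series" means these few. Any claim that something is new, unique, unknown or untested is made for them only; others in the source may bear on it.

Compound 1 `CSc1cnc2ccccc2c1SCC#CCCl`: 2.7 ug/mL
Compound 2 `CSc1cnc2ccccc2c1[Se]CC#CCOC(=O)c1ccccc1`: 3.5 ug/mL

Two measured compounds share the same core and differ in the chain that hangs from it. In a functional assay on P388 cells (Mus musculus) for antiproliferative activity, with a stated time of 72 h (a higher number here means a weaker inhibitor, a lower number a stronger inhibitor), compound 1 gives 2.7 ug/mL and compound 2 gives 3.5 ug/mL. The two values lie within the scatter of each other, so the numbers shown do not separate compound 2 from compound 1; compound 2 simply sits alongside it.

Compound 3 `CSc1cnc2ccccc2c1[Se]CC#CCO` has not yet been measured. It differs from compound 2 at the end of the chain: hydrogen in place of benzoyl on an oxygen on a saturated carbon. The benzoyl group leaves and a hydrogen atom takes its place on the oxygen on a saturated carbon.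

For the measured compounds named here, no measured pair shows what such a change does in this assay, so no direction can be read from the two numbers at hand. With nothing to point either way, the step is expected to stay within the scatter. Compound 3 is expected to give 3.5 ug/mL in this assay, with a range from 1.2 ug/mL to 10 ug/mL. That estimate means a step of no change at the digits printed from compound 2 to compound 3 (within the scatter) that is expected to be no larger than the scatter.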

Compound 3, concentration for 50% inhibition: 2.6 ug/mL
The estimate for compound 3 lay 1.3-fold (0.13 log units) above the measured number, within the range that was stated.
By their numbers in this assay, from the lowest: compounds 3, 1 and 2 (each within the scatter of the next).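

In this assay, the hydrogen in place of benzoyl on an oxygen on a saturated carbon gives a 1.3-fold lower number from compound 2 to compound 3 (0.13 log units; within the scatter) and so shows that, at this position, the whole benzoyl group can go without the two numbers separating. For the compounds shown here, this is the first measured step at the end of the chain, and it covers only this one pair. The second step exchanges the entire group on an aromatic carbon, with the sulfur and chlorine of compound 1 giving way to the selenium and oxygen of compound 3, and it gives a 1.0-fold lower number from compound 1 to compound 3 (0.02 log units; within the scatter) so that this larger exchange does not separate the numbers either.

From the compounds shown here alone, whether an acetyl or a methyl group on that oxygen, or an amine or a carboxylic acid at the end of the chain, would stay within the scatter of compound 3 remains open. The compounds shown also hold no pair in which selenium and sulfur are exchanged alone, so the part played by each atom in this assay cannot be told apart. No accompanying measurement bears on these results.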